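The compounds below may be only part of what the source reports. "The series", "measured", "known", "first", "only" and "open" are said of these compounds alone.

Compound 3 `Cn1cc(CNS(=O)(=O)c2ccccc2Nc2cc(-c3ccc4ccn(C)c4c3)c3nccnc3c2)cn1` sits second highest of the three numbers measured in an assay for inhibition of 6-phosphofructo-2-kinase/fructose-2,6-bisphosphatase 3 (Homo sapiens), read by ADP-Glo, with a stated time of 2 h (a higher number here means a weaker inhibitor, a lower number a stronger inhibitor), where compound 3 gives 38 nM. For the measured compounds named here, its nearest neighbour is compound 1 `Cn1ccc2ccc(-c3cc(Nc4ccccc4S(=O)(=O)N4CCOCC4)cc4nccnc34)cc21`, which in this assay gives 36 nM; the only other measured compound, compound 2 `CN1CCCC(NS(=O)(=O)c2ccccc2Nc2cc(-c3ccc4ccn(C)c4c3)c3nccnc3c2)C1`, gives 59 nM. None of the three stands apart from the others.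

Compound 4 `Cn1ccc2ccc(-c3cc(Nc4ccccc4S(=O)(=O)NCC4CCOCC4)cc4nccnc34)cc21` is reached from compound 3 by a change at the sulfonamide nitrogen: oxan-4-yl in place of 1-methyl-1H-pyrazol-4-yl on a saturated chain carbon bound to a sulfonamide nitrogen. The earlier steps shown here that bear on this are those which also alter the group carried on the sulfonyl sulfur or the sulfonamide nitrogen. From compound 1 to compound 3 the change gave a 1.1-fold higher number from compound 1 to compound 3 (0.02 log units; within the scatter); from compound 1 to compound 2 it gave a 1.6-fold higher number from compound 1 to compound 2 (0.21 log units; within the scatter); and from compound 2 to compound 3 it gave a 1.6-fold lower number from compound 2 to compound 3 (0.19 log units; within the scatter). Every one of these exchanges at this position left the number within the scatter, so a further exchange of one ring for another at the same place is expected to move the number by no more than the scatter, in no particular direction.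

Compound 4 is therefore estimated at 40 nM in this assay, with a range from 20 nM to 85 nM, an expected step of a 1.1-fold higher number from compound 3 to compound 4 (0.02 log units; within the scatter) from compound 3.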

Compound 4, half-maximal inhibitory concentration: 26 nM
Compound 4: middle estimate off by 1.5-fold (0.19 log units), on the high side; measured number inside the range.
By their numbers in this assay, from the lowest: compounds 4, 1, 3 and 2 (each within the scatter of the next, the first and the last beyond it).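

In this assay, oxan-4-yl and 1-methyl-1H-pyrazol-4-yl on a saturated chain carbon bound to a sulfonamide nitrogen are not told apart (a 1.5-fold lower number from compound 3 to compound 4 (0.16 log units; within the scatter)), so at this place a six-membered non-aromatic ring with 1 hetero atom and a five-membered aromatic ring with 2 hetero atoms read alike, and ((oxan-4-yl)methyl)amino in place of morpholin-4-yl on a sulfonyl sulfur also stays within the scatter (a 1.4-fold lower number from compound 1 to compound 4 (0.14 log units; within the scatter)). For the compounds shown here, what the earlier compounds did not show is a step beyond the scatter among the groups at this position: (oxan-4-yl)methyl in place of 1-methylpiperidin-3-yl on a sulfonamide nitrogen gives a modest one (a 2.3-fold lower number from compound 2 to compound 4 (0.36 log units; beyond the scatter)). Nothing measured here bears on why these groups give these numbers.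

The compounds shown leave open whether (oxan-4-yl)ethyl, a longer chain, in place of (oxan-4-yl)methyl would keep the number in this range, and whether a carboxylic acid or a primary amine on the saturated chain carbon would do the same. They also leave open whether these exchanges would read the same on a different core.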